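Rearranging the Pyridine Ring on the Alkyne Linker

This account rests on a few compounds, and the source may have more. Where it says the series, first, only, none or still open, it means among the compounds named here.

Among the measured compounds shown here, compound 2 `C#Cc1cncc(C#Cc2ccc3ncn(-c4ccnc(N)n4)c3c2)c1` gives the highest of the two numbers measured so far in an assay on Sf9 cells for inhibition of mitogen-activated protein kinase kinase kinase 14 variant S549D (Homo sapiens), with a stated time of 30 min, in the presence of a further agent that is not named here (a higher number here means a weaker inhibitor, a lower number a stronger inhibitor), at 63100 nM. Compound 1 `C=Cc1ccnc(C#Cc2ccc3ncn(-c4ccnc(N)n4)c3c2)c1` gives 1580 nM in this assay. Compound 3 `C#Cc1ccnc(C#Cc2ccc3ncn(-c4ccnc(N)n4)c3c2)c1` differs from compound 2 by a group of 8 heavy atoms (7 carbon, 1 nitrogen; one six-membered aromatic ring with 1 hetero atom) in place of a group of 8 heavy atoms (7 carbon, 1 nitrogen; one six-membered aromatic ring with 1 hetero atom), on a triple-bonded carbon. For the measured compounds named here, the single measured step that bears on this change, a 40-fold higher number from compound 1 to compound 2 (1.60 log units; beyond the scatter), was large, and the 4-ethynylpyridin-2-yl group of compound 3 brings it closer to compound 1 than compound 2 is. The number is therefore expected to fall markedly in this assay, a 21-fold lower number from compound 2 to compound 3 (1.32 log units; beyond the scatter). Compound 3 is estimated at 3000 nM, within a range from 800 nM to 12000 nM.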

Compound 3, half-maximal inhibitory concentration: 316 nM
For compound 3 the middle estimate is 9.5-fold (0.98 log units) above the measured one; the measured number lies below the stated range.
By their numbers in this assay, from the lowest: compound 3; then compound 1; then compound 2.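

With the same atoms joined differently, the 4-ethynylpyridin-2-yl group on the triple-bonded carbon gives a 200-fold lower number from compound 2 to compound 3 (2.30 log units; beyond the scatter) in this assay and so shows that the arrangement of this ring alone can change the number greatly. Ethynyl in place of vinyl on an aromatic carbon gives a more modest change, a 5.0-fold lower number from compound 1 to compound 3 (0.70 log units; beyond the scatter) and this too lies beyond the usual scatter. Nothing available here accounts for either step.

On these data alone, it remains open how a nitrile, an amine or a longer chain in place of ethynyl would read in this assay on this pyridine. Whether any such group would lower the number further is also unsettled.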